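Swapping methoxy for chloro on the aryl piperazine

A few compounds are considered here, and "the series" means these few. Any claim that something is new, unique, unknown or untested is made for them only; others in the source may bear on it.

Compound 1 `COc1ccccc1N1CCN(CCCn2nc(-n3cnc4ccccc43)ccc2=O)CC1` and compound 2 `COc1ccccc1N1CCN(CCCCn2nc(-n3cnc4ccccc43)ccc2=O)CC1` share a core and differ in the chain joining its two parts; the difference between the two cores is not broken down here. In an assay on cell membranes from brain for binding affinity to Adrenergic receptor alpha-1 (Rattus norvegicus), read by radioligand binding (a lower number here means a stronger inhibitor, a higher number a weaker inhibitor), compound 1 gives 6.5 nM, while compound 2 gives 1.1 nM, the lowest of the three numbers. Compound 3 `O=c1ccc(-n2cnc3ccccc32)nn1CCCN1CCN(c2ccccc2Cl)CC1` carries the change chloro in place of methoxy on an aromatic carbon on compound 1, and in this assay compound 3 gives 15.2 nM, a step of a 2.3-fold higher number from compound 1 to compound 3 (0.37 log units; beyond the scatter). Compound 4 `O=c1ccc(-n2cnc3ccccc32)nn1CCCCN1CCN(c2ccccc2Cl)CC1` carries the same change on compound 2, (chloro in place of methoxy on an aromatic carbon). Because the measured step of a 2.3-fold higher number from compound 1 to compound 3 (0.37 log units; beyond the scatter) is modest, the new step is expected to be a 2.3-fold higher number from compound 2 to compound 4 (0.36 log units; beyond the scatter), of similar size, resting on that single precedent. Compound 4 is therefore expected at 2.5 nM, between 1 nM and 7 nM.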

Compound 4, inhibition constant: 1.3 nM
Estimate against measurement, compound 4: 1.9-fold (0.28 log units) above, and the stated range covers the measured number.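

In this assay replacing 2-methoxyphenyl with 2-chlorophenyl on the core of compound 2 gives a 1.2-fold higher number from compound 2 to compound 4 (0.07 log units; within the scatter) and so leaves no readable mark on this core. Set beside the same change on the core of compound 1, the two steps cannot be told apart: the same change on two cores in this assay, a 2.3-fold higher number (0.37 log units; beyond the scatter) from compound 1 to compound 3 and a 1.2-fold higher number (0.07 log units; within the scatter) from compound 2 to compound 4, 2.0-fold (0.30 log units) apart, within the scatter of two such steps. On these two cores the change therefore carries over without a measurable difference in step size, but two pairs in one assay cannot show that it would do so on other cores, nor why.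

The compounds shown leave open whether other groups in the same place, such as fluoro, methyl or nitrile, would behave alike on both cores. They also leave open what a longer chain than that of compound 2 would do in this assay to the measured number.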